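The source may hold more compounds than are shown below. What is called first, only, known or untested is meant among the compounds shown, and "the series" means these compounds.

The measured compounds and their values in a functional assay on MGC-803 cells (Homo sapiens) for inhibition, read by sulforhodamine B assay (on this read-out higher numbers stand for weaker inhibition and lower numbers for stronger inhibition), are as follows.

Compound 1 `O=C1C=C(NCc2ccccc2)C(=O)c2c1nc1n2[C@H]2OC[C@@H](O)[C@H]2OC1` gives 2670 nM.
Compound 2 `O=C1C(Nc2ccccc2F)=CC(=O)c2c1nc1n2[C@H]2OC[C@@H](O)[C@H]2OC1` gives 2000 nM.
Compound 3 `Cc1ccc(NC2=CC(=O)c3c(nc4n3[C@H]3OC[C@@H](O)[C@H]3OC4)C2=O)cc1` gives 1550 nM.

Among these three, compound 1 carries the highest number, but its gap to compound 2, the nearest, and to compound 3, the furthest, both lie within the usual scatter, so the three compounds cannot be placed in any order on this read-out. Among the compounds with values here, the one measured step, a 1.3-fold lower number from compound 2 to compound 3 (0.11 log units; within the scatter), exchanges one aryl group for another on the amine nitrogen and is itself within the scatter.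

Compound 4 `O=C1C=C(N2CCCCC2)C(=O)c2c1nc1n2[C@H]2OC[C@@H](O)[C@H]2OC1` departs from compound 1 by a different kind of change: piperidin-1-yl in place of benzylamino on a double-bonded ring carbon. Within the data shown here, no measured step touches this exchange; the step from compound 2 to compound 3 keeps an aromatic group on the nitrogen throughout and keeps its hydrogen-bond donor, whereas here a non-aromatic ring with no hydrogen-bond donor enters. Among the measured compounds shown here, the data therefore give no direction for this step, and the most that can be said is that the measured exchanges on this position have all stayed within the scatter.

Compound 4 is accordingly expected to lie near compound 1, at about 3000 nM, with a range from 1200 nM to 8000 nM. That estimate corresponds to an expected step of a 1.1-fold higher number from compound 1 to compound 4 (0.05 log units; within the scatter), with a wide margin in either direction.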

Compound 4, half-maximal inhibitory concentration: > 8000 nM
Compound 4 gave a limit, no number; the forecaster's own chance of this, stated with the estimate: 10%; middle value at least 2.6-fold (0.42 log units) away from the limit.
By their numbers in this assay, from the lowest: compounds 3, 2 and 1 (each within the scatter of the next). At a limit, above all of these: compound 4.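

In this assay the reading for compound 4 is a limit of the assay and not a number: the limit of > 8000 nM in this assay, at which 1 of the 4 values shown sits.

Even read as a limit, the exchange of benzylamino for piperidin-1-yl gives an at least 2.9-fold higher number from compound 1 to compound 4 (0.47 log units; beyond the scatter), the only step among the compounds shown that lies beyond the scatter. Compounds 1, 2 and 3 all keep a hydrogen-bond donor on the nitrogen and an aromatic ring in the group and could not be placed in any order, whereas compound 4 shows that this double-bonded ring carbon does not tolerate every group equally on this read-out.

The change to compound 4 removes the aromatic ring and the hydrogen-bond donor together and also alters the size of the group, so the compounds shown leave open which of these differences goes with the step, and how far compound 4 really lies past its limit. Cyclohexylamino would keep the amine hydrogen on a non-aromatic ring and benzyl(methyl)amino would keep the aromatic ring without that hydrogen, and the values of such groups would separate the two.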